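From 4-methylbenzyl to 4-fluorobenzyl: compound 3 and compound 4

The compounds below may be only part of what the source reports. "The series", "measured", "known", "first", "only" and "open" are said of these compounds alone.

In a functional assay on Jurkat cells (Homo sapiens) for inhibition, read by CCK-8 assay, with a stated time of 48 h (on this read-out higher numbers stand for weaker inhibition of growth and lower numbers for stronger inhibition of growth), compound 1 `CN1CCN(c2ccc(Nc3ncc(Cl)c(NCc4ccccc4)n3)nc2)CC1` reads > 100000 nM, which is a limit of the assay. Compound 2 `CN1CCN(c2ccc(Nc3ncc(Cl)c(NCc4ccc(C(F)(F)F)cc4)n3)nc2)CC1` gives 7960 nM and compound 3 `Cc1ccc(CNc2nc(Nc3ccc(N4CCN(C)CC4)cn3)ncc2Cl)cc1` gives 12700 nM. These two values stand together, with a 1.6-fold higher number from compound 2 to compound 3 (0.20 log units; within the scatter).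

Compound 4 `CN1CCN(c2ccc(Nc3ncc(Cl)c(NCc4ccc(F)cc4)n3)nc2)CC1` carries fluoro in place of methyl on an aromatic carbon, para to a large group (fluoro in place of methyl on an aromatic carbon). For the measured compounds named here, no measured step covers this exchange directly. Going by the values given here, two steps bear on it: methyl in place of hydrogen gave an at least 7.8-fold lower number from compound 1 to compound 3 (0.89 log units; beyond the scatter), and trifluoromethyl in place of hydrogen gave an at least 12-fold lower number from compound 1 to compound 2 (1.09 log units; beyond the scatter). Following these steps, a small move towards weaker inhibition is expected, estimated as a 1.6-fold higher number from compound 3 to compound 4 (0.20 log units; within the scatter). Compound 4 is therefore expected at 20000 nM, within an estimated range of 7000 nM to 70000 nM.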

Compound 4, concentration for 50% growth inhibition: > 100000 nM
Compound 4: no number, only a limit; the forecaster's own chance of this, stated with the estimate: 10%; middle value at least 5.0-fold (0.69 log units) away from the limit.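

Para to a large group, fluoro does not go the way of methyl or trifluoromethyl: the exchange gives an at least 7.8-fold higher number from compound 3 to compound 4 (0.89 log units; beyond the scatter), and an at least 12-fold higher number from compound 2 to compound 4 (1.09 log units; beyond the scatter). In this assay compound 4 gives > 100000 nM, which is a limit, so a group at this position does not by itself bring a measurable number. The step between compound 1 and compound 4 cannot be read, since both sit at the same limit: the limit of > 100000 nM in this assay, at which 2 of the 4 values shown sit.

From the compounds shown here alone, whether chloro, methoxy or an amine at this position would give a measurable number stays open.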